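A few compounds are considered here, and "the series" means these few. Any claim that something is new, unique, unknown or untested is made for them only; others in the source may bear on it.

Measured so far in an ADME assay on microsomes from liver (Homo sapiens) for metabolic stability, read by LC-MS, using NADPH, tested at 5 uM; a higher number here means that the compound lasts longer, a lower number that the compound disappears faster: compound 1 `CN1CCN(Cc2nnc(-c3cc(S(N)(=O)=O)c(SCc4ccccc4)cc3Cl)o2)CC1` gives 0.308 h, and compound 2 `NS(=O)(=O)c1cc(-c2nnc(CN3CCN(c4ccc(F)cc4)CC3)o2)c(Cl)cc1SCc1ccccc1` gives 0.527 h.

For the measured compounds named here, compound 1 and compound 2 sit within the scatter of each other, the one measured step, a 1.7-fold higher number from compound 1 to compound 2 (0.23 log units; within the scatter), being within it. Compound 3 `NC(=O)c1cn(Cc2nnc(-c3cc(S(N)(=O)=O)c(SCc4ccccc4)cc3Cl)o2)nn1` differs from compound 1 by 4-carbamoyl-1H-1,2,3-triazol-1-yl in place of 4-methylpiperazin-1-yl on a saturated chain carbon bound to an aromatic carbon. The measured step only swaps the methyl on the ring nitrogen while keeping the ring; nothing measured bears on replacing that ring altogether. No change beyond the scatter is therefore expected. Compound 3 is estimated to give 0.35 h, between 0.15 h and 0.8 h, an expected step of a 1.1-fold higher number from compound 1 to compound 3 (0.06 log units; within the scatter).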

Compound 3, half-life: 0.435 h
Beside the measured number, compound 3's estimate is 1.2-fold (0.09 log units) below it, and the stated range covers the measured number.
By their numbers in this assay, from the lowest: compounds 1, 3 and 2 (each within the scatter of the next).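

In this assay, replacing the whole 4-methylpiperazin-1-yl ring with 4-carbamoyl-1H-1,2,3-triazol-1-yl on a saturated chain carbon bound to an aromatic carbon gives a 1.4-fold higher number from compound 1 to compound 3 (0.15 log units; within the scatter). At this place, then, a change of the entire ring, and not only of the methyl on its nitrogen, can leave the half-life within the scatter. No supporting data are available to account for this result. Still open, from the compounds shown here alone, is whether any group at this place moves the half-life beyond the scatter, for example a carboxylic acid or an open-chain amine.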